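The source may report more compounds than this note shows. Statements on the series, on what has been measured and on what is new or still open speak of the compounds shown alone.

Measured so far:
compound 1 `O=C(CN1CCN(c2cc3c(cc2F)c(=O)c(C(=O)O)cn3C2CC2)CC1)Nc1ccc(C(=O)/C=C/c2ccccc2)cc1` — 1.29
compound 2 `O=C(CN1CCN(c2cc3c(cc2F)c(=O)c(C(=O)O)cn3C2CC2)CC1)Nc1ccc(C(=O)/C=C/c2cccc(Cl)c2)cc1` — 0.302
compound 3 `O=C(CN1CCN(c2cc3c(cc2F)c(=O)c(C(=O)O)cn3C2CC2)CC1)Nc1ccc(C(=O)/C=C/c2ccc(Cl)cc2)cc1` — 0.471

In a physicochemical assay for lipophilicity, using the shake flask method, in phosphate buffer, measured as octanol-water partition, with a stated time of 5 h (a higher number here means a more lipophilic compound, a lower number a more polar compound), compound 3 stands second highest of the three: a number 0.17 log units higher from compound 2 to compound 3 (within the scatter), and a number 0.82 log units lower from compound 1 to compound 3 (beyond the scatter). Compound 4 `COc1ccc(/C=C/C(=O)c2ccc(NC(=O)CN3CCN(c4cc5c(cc4F)c(=O)c(C(=O)O)cn5C4CC4)CC3)cc2)cc1` is compound 3 with methoxy in place of chloro on an aromatic carbon. Going by the values given here, no measured pair carries this exchange. Among the compounds with values here, the steps that bear on this ring are a number 0.99 log units lower from compound 1 to compound 2 (beyond the scatter) and a number 0.82 log units lower from compound 1 to compound 3 (beyond the scatter), both modest and beyond the scatter, and a number 0.17 log units higher from compound 2 to compound 3 (within the scatter), within the scatter. With nothing measured on methoxy, the expectation for compound 4 in this assay is a small shift, a number 0.13 log units higher from compound 3 to compound 4 (within the scatter), with a wide range. The estimate for compound 4 is 0.6, expected between 0 and 1.3.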

Compound 4, partition coefficient: 0.684
The estimate for compound 4 lay 0.08 log units below the measured number; the range from low to high includes it.
By their numbers in this assay, from the lowest: compounds 2, 3 and 4 (each within the scatter of the next, the first and the last beyond it); then compound 1.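

On the aromatic carbon para to a large group, methoxy and chloro cannot be told apart in this assay (a number 0.21 log units higher from compound 3 to compound 4 (within the scatter)). Methoxy in place of hydrogen also gives a lower number (a number 0.61 log units lower from compound 1 to compound 4 (beyond the scatter)), so the drop from compound 1 is not confined to chloro, and 4-methoxyphenyl stands clear of 3-chlorophenyl (a number 0.38 log units higher from compound 2 to compound 4 (beyond the scatter)). No measurement available here accounts for these steps.

On these data alone, whether an amine or a longer alkyl chain on this aromatic carbon would also fall below compound 1 remains open.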